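Shortening one sulfur chain on a quinoline-free core

The source may report more compounds than this note shows. Statements on the series, on what has been measured and on what is new or still open speak of the compounds shown alone.

Measured compounds:
compound 1 `OCC#CCSc1cnc2ccccc2c1SCC#CCO`, 32 ug/mL
compound 2 `C[Se]c1c(SCC#CCO)cnc2ccccc12`, 3.5 ug/mL
compound 3 `C#CC[Se]c1c(SCC#CCO)cnc2ccccc12`, 3.8 ug/mL

In a functional assay on SW707 cells (Homo sapiens) for cytotoxicity, read by sulforhodamine B assay, with a stated time of 72 h (a lower number here means a stronger inhibitor, a higher number a weaker inhibitor), compound 1 gives the highest of the three numbers, so it is the weakest of these three. Compound 4 `CSc1cnc2ccccc2c1SCC#CCO` differs from compound 1 in one place: hydrogen in place of 3-hydroxyprop-1-yn-1-yl on a saturated chain carbon bound to a sulfur. Among the compounds with values here, no measured step changes the sulfur chain in this way while keeping the sulfur. The nearest guides replace the whole group on the aromatic carbon with a smaller selenium group, giving a 9.1-fold lower number from compound 1 to compound 2 (0.96 log units; beyond the scatter) and an 8.4-fold lower number from compound 1 to compound 3 (0.93 log units; beyond the scatter). A smaller group at that place went with a lower number both times, so a modest decrease is expected here, with wide uncertainty. Compound 4 is estimated at 12 ug/mL, in the range 4 ug/mL to 35 ug/mL, meaning a 2.7-fold lower number from compound 1 to compound 4 (0.43 log units; beyond the scatter).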

Compound 4, concentration for 50% inhibition: 34.9 ug/mL
Compound 4: middle estimate off by 2.9-fold (0.46 log units), on the low side; the range from low to high includes it.
By their numbers in this assay, from the lowest: compounds 2 and 3 (each within the scatter of the next); then compounds 1 and 4 (each within the scatter of the next).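

In this assay the change from 4-hydroxybut-2-yn-1-yl to methyl gives a 1.1-fold higher number from compound 1 to compound 4 (0.04 log units; within the scatter), so shortening this sulfur chain alone leaves the number unmoved. Compound 4 and compound 2 share the methyl group and differ only in sulfur or selenium, yet compound 4 gives 34.9 ug/mL and compound 2 gives 3.5 ug/mL. Nothing available explains either result.

From the compounds shown here alone, whether an ethyl group or an amine-bearing chain at this place would also leave the number unmoved stays open. So does whether the remaining 4-hydroxybut-2-yn-1-yl chain can be shortened in the same way.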